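The source may hold more compounds than are shown below. What is called first, only, known or untested is meant among the compounds shown, and "the series" means these compounds.

Measured so far:
Compound 1 `O=C(Nc1cccc(-n2cc(-c3ccncc3)c(-c3ccc(Cl)c(O)c3)n2)c1)Nc1ccc(Cl)c(Cl)c1`: 7220 nM
Compound 2 `O=C(Nc1cccc(-n2cc(-c3ccncc3)c(-c3ccc(Cl)c(O)c3)n2)c1)Nc1cc(C(F)(F)F)cc(C(F)(F)F)c1`: 1170 nM
Compound 3 `COc1cc(-c2nn(-c3cccc(NC(=O)c4ccccc4)c3)cc2-c2ccncc2)ccc1Cl`: 1520 nM

These three compounds were tested in a functional assay on 786-0 cells (Homo sapiens) for inhibition, read by sulforhodamine B assay, with a stated time of 48 h; on this read-out higher numbers stand for weaker inhibition of growth and lower numbers for stronger inhibition of growth. Compound 1 has the highest number of the three, meaning the weakest inhibition of growth in this set. Compound 3 comes nearest to it, and compound 2 lies furthest from it; both gaps are beyond the usual scatter of this kind of measurement, so compound 1 stands apart as the weakest of the three.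

The next compound, compound 4 `O=C(Nc1cccc(-n2cc(-c3ccncc3)c(-c3ccc(Cl)c(O)c3)n2)c1)Nc1ccc(Cl)c(C(F)(F)F)c1`, is compound 1 with one change: trifluoromethyl in place of chloro on an aromatic carbon. Within the shared core nothing else moves.

Going by the values given here, no pair of measured compounds differs in exactly one place, so no measured step tells directly what this change does. Compound 2, which carries two trifluoromethyl groups on the same ring, gives a lower number than compound 1 in this assay, and that is the only hint here. On that hint, compound 4 is expected to show a moderate step downward in this assay, one that may just exceed the scatter, of size a 2.3-fold lower number from compound 1 to compound 4 (0.35 log units; beyond the scatter). The estimated value for compound 4 is 3200 nM, with a range from 1300 nM to 8000 nM.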

Compound 4, concentration for 50% growth inhibition: 1280 nM
Compound 4: the middle estimate sits 2.5-fold (0.40 log units) above what was measured; measured number outside the range, below it.
By their numbers in this assay, from the lowest: compounds 2, 4 and 3 (each within the scatter of the next); then compound 1.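

Swapping one chloro for trifluoromethyl, on the aromatic carbon ortho to a chloro group and meta to a large group, gives a 5.6-fold lower number from compound 1 to compound 4 (0.75 log units; beyond the scatter) in this assay. Going by these compounds alone, this is the first direct reading of a single change on this ring, and it shows that the ring position accepts a group of four heavy atoms in place of one, with growth inhibition becoming stronger rather than weaker. The data shown offer no measurement that accounts for this gain in growth inhibition.

From the compounds shown here alone, one step between two compounds cannot separate the contribution of the trifluoromethyl group from that of simply having a larger group on this carbon, so it remains open how a methyl group, a nitrile or an amine at the same place would compare with the chloro of compound 1 and the trifluoromethyl of compound 4. Also open, going by these compounds, is whether the same swap would give a step of similar size if the other chloro on this ring were replaced, or if the hydroxyl on the opposite side of the molecule were changed.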